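Working notes on the step from compound 3 to compound 4

The compounds below may be only part of what the source reports. "The series", "measured", "known", "first", "only" and "open" are said of these compounds alone.

Measured so far in an assay on isolated protein for inhibition of Indoleamine 2,3-dioxygenase 2 (Homo sapiens); on this read-out higher numbers stand for weaker inhibition and lower numbers for stronger inhibition:
- compound 1 `OCc1cn(CCNc2nonc2/C(=N/O)Nc2ccc(F)c(Br)c2)nn1` gives 794 nM
- compound 2 `CC(O)c1cn(CCNc2nonc2/C(=N/O)Nc2ccc(F)c(Br)c2)nn1` gives 362 nM
- compound 3 `CCC(C)(O)c1cn(CCNc2nonc2/C(=N/O)Nc2ccc(F)c(Br)c2)nn1` gives 958 nM

Compound 3 carries the highest number of the three; its gap to compound 1 lies within the scatter, while a 2.6-fold higher number from compound 2 to compound 3 (0.42 log units; beyond the scatter) lies beyond it. Compound 4 `OCCOCc1cn(CCNc2nonc2/C(=N/O)Nc2ccc(F)c(Br)c2)nn1` differs by (2-hydroxyethoxy)methyl in place of 1-hydroxy-1-methylpropyl on an aromatic carbon. Among the compounds with values here, no measured step swaps one chain for another of this kind; the nearest comparisons are a 1.2-fold higher number from compound 1 to compound 3 (0.08 log units; within the scatter) and a 2.6-fold higher number from compound 2 to compound 3 (0.42 log units; beyond the scatter), both small. The expectation in this assay is therefore no step beyond the scatter, or at most a modest move toward a lower number, as compound 1 with hydroxymethyl gave 794 nM. Compound 4 is estimated at 700 nM with a range of 250 nM to 2000 nM. The expected step is a 1.4-fold lower number from compound 3 to compound 4 (0.14 log units; within the scatter).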

Compound 4, half-maximal inhibitory concentration: 144 nM
Compound 4: middle estimate off by 4.9-fold (0.69 log units), on the high side; the whole stated range lies above it.
By their numbers in this assay, from the lowest: compound 4; then compound 2; then compounds 1 and 3 (each within the scatter of the next).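

Within the data shown here, this position on the five-membered aromatic ring accepts more than the short hydroxyalkyl groups showed: in this assay, (2-hydroxyethoxy)methyl gives the lowest number so far (a 6.7-fold lower number from compound 3 to compound 4 (0.82 log units; beyond the scatter)) and (a 2.5-fold lower number from compound 2 to compound 4 (0.40 log units; beyond the scatter)). Extending the oxygen of hydroxymethyl with 2-hydroxyethyl (a 5.5-fold lower number from compound 1 to compound 4 (0.74 log units; beyond the scatter)) reaches lower than either branched hydroxyalkyl group, so the chain need not stay short. No supporting data explain this step.

The compounds shown leave open whether the terminal hydroxyl matters, which a methoxy or an amine at the chain end would test. On these data alone, whether a longer chain lowers the number further also stays open.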